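Chain length on the ester tail and cytotoxicity

This account rests on a few compounds, and the source may have more. Where it says the series, first, only, none or still open, it means among the compounds named here.

Measured compounds:
compound 1, `CCCOC(=O)CCC(=O)N1CCN(CCCOc2cc3c(Nc4ccc(F)c(Cl)c4)ncnc3cc2OC)CC1`, gives 87%
compound 2, `CCCCOC(=O)CCC(=O)N1CCN(CCCOc2cc3c(Nc4ccc(F)c(Cl)c4)ncnc3cc2OC)CC1`, gives 86%
compound 3, `CCCCCCCCCOC(=O)CCC(=O)N1CCN(CCCOc2cc3c(Nc4ccc(F)c(Cl)c4)ncnc3cc2OC)CC1`, gives 79.7%

All three share one core and differ only in how long the alkyl chain on the ester is. They were tested in a functional assay on A549 cells (Homo sapiens) for cytotoxicity, read by MTT assay, with a stated time of 24 h, tested at 20 uM; on this read-out higher numbers stand for a weaker effect at the one concentration tested and lower numbers for a stronger effect. The change from compound 1 to compound 2 is methyl in place of hydrogen on a saturated chain carbon, three bonds along the chain from an oxygen next to a carbonyl group, and it made a step of a number 1 percentage points lower from compound 1 to compound 2 (within the scatter). The longer extension from compound 1 to compound 3 gave a number 7.3 percentage points lower from compound 1 to compound 3 (within the scatter), and from compound 2 to compound 3 a number 6.3 percentage points lower from compound 2 to compound 3 (within the scatter); none of these moves is beyond the scatter.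

Compound 4, `CCCCCCCCCCOC(=O)CCC(=O)N1CCN(CCCOc2cc3c(Nc4ccc(F)c(Cl)c4)ncnc3cc2OC)CC1`, is not yet measured. It arises from compound 3 by methyl in place of hydrogen on a saturated chain carbon, nine bonds along the chain from an oxygen next to a carbonyl group. The cores of compound 1 and compound 3 differ by hexyl in place of hydrogen on a saturated chain carbon, three bonds along the chain from an oxygen next to a carbonyl group. The two places are not worded alike: in one the methyl enters three bonds along the chain from an oxygen next to a carbonyl group, in the other nine bonds along the chain, so this is the same kind of change rather than the same change.

The step from compound 3 to compound 4 is expected to be a number 1.7 percentage points lower from compound 3 to compound 4 (within the scatter), because a number 1 percentage points lower from compound 1 to compound 2 (within the scatter) stayed within the scatter. Compound 4 is therefore estimated at 78%, with a likely range from 68% to 88%.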

Compound 4, a percentage reported as activity, at one concentration (the size of the read-out at that concentration, not a potency): 88.2%
Compound 4: the middle estimate sits 10.2 percentage points below what was measured, and the stated range ends below it.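

In this assay, methyl in place of hydrogen nine bonds along the chain from an oxygen next to a carbonyl group gave a number 8.5 percentage points higher from compound 3 to compound 4 (within the scatter), and set beside the same kind of change on the core of compound 1, it shows no difference beyond the scatter: the same change on two cores in this assay, a number 1 percentage points lower (within the scatter) from compound 1 to compound 2 and a number 8.5 percentage points higher (within the scatter) from compound 3 to compound 4, 9.5 percentage points apart, within the scatter of two such steps. The larger extensions gave a number 2.2 percentage points higher from compound 2 to compound 4 (within the scatter) and a number 1.2 percentage points higher from compound 1 to compound 4 (within the scatter), and the hexyl change also shows no difference beyond the scatter between its two cores: the same change on two cores in this assay, a number 7.3 percentage points lower (within the scatter) from compound 1 to compound 3 and a number 2.2 percentage points higher (within the scatter) from compound 2 to compound 4, 9.5 percentage points apart, within the scatter of two such steps. So nothing here speaks against carrying these changes from one core to another, but with every step inside the scatter, this does not show that any of them has a real effect of its own, or that such an effect would carry over.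

The compounds shown are all unbranched alkyl esters on the shared core. As far as these compounds go, what a carboxylic acid or an amine at the end of the tail, or a longer chain, would give remains open.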